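Iodo for Fluoro on Two Related Cores

The compounds below may be only part of what the source reports. "The series", "measured", "known", "first", "only" and "open" are said of these compounds alone.

This study asks how tolerance of a compound by mouse macrophage cells shifts when one small group on an aromatic ring is exchanged. Compound 1 `O=C(Nc1ccc(F)cc1F)c1ccccc1OCc1ccc(F)cc1F` is an open amide. Compound 2 `O=c1oc2ccccc2c(=O)n1-c1ccc(F)cc1F` has a different, closed core; the difference between the two cores is not broken down here. Compound 3 `O=C(Nc1ccc(I)cc1F)c1ccccc1OCc1ccc(F)cc1F` is compound 1 with iodo in place of fluoro on an aromatic carbon. Compound 4 `O=c1oc2ccccc2c(=O)n1-c1ccc(I)cc1F`, not yet measured, is compound 2 with iodo in place of fluoro on an aromatic carbon; the surroundings of the exchanged atom read the same in both pairs, so this is the same change made on a second core.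

In an ADME assay on RAW264.7 cells (Mus musculus) for cytotoxicity, read by MTT assay, with a stated time of 24 h (a lower number here means that less compound is tolerated, a higher number that more compound is tolerated), compound 1 reaches only the limit of the assay, > 40000 nM. In this assay compound 2 likewise reaches only the limit, > 40000 nM. In this assay compound 3 gives 32600 nM. The exchange therefore made an at least 1.2-fold lower number from compound 1 to compound 3 (0.08 log units; that floor lies within the scatter), and because the limit of > 40000 nM in this assay, at which 2 of the 3 values shown sit, caps the starting point, the true size of that step is not known.

Going by the values given here, because an at least 1.2-fold lower number from compound 1 to compound 3 (0.08 log units; that floor lies within the scatter) is the only measured step of this kind, the expected step is an at least 1.1-fold lower number from compound 2 to compound 4 (0.05 log units; that floor lies within the scatter). Compound 4 is therefore estimated at 35000 nM, with the range 18000 nM to 70000 nM, and the assay may again report only a limit rather than a number.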

Compound 4, half-maximal cytotoxic concentration: 23600 nM
Estimate against measurement, compound 4: 1.5-fold (0.17 log units) above; measured number inside the range.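

On both cores in this assay, the compound with iodo gives a measured number, while its partner with fluoro reaches only the limit of the assay, and the new exchange gives an at least 1.6-fold lower number from compound 2 to compound 4 (0.22 log units; that floor lies within the scatter). Compound 2 gives > 40000 nM, which is a limit and not a number. So the change can be said to behave alike on the two cores only in this plain sense, and neither the true size of each step nor any gap between them can be read: the same change on two cores in this assay, an at least 1.2-fold lower number (0.08 log units; that floor lies within the scatter) from compound 1 to compound 3 and an at least 1.6-fold lower number (0.22 log units; that floor lies within the scatter) from compound 2 to compound 4; the limit leaves it open whether they differ

The compounds shown hold only fluoro or iodo at this place on the ring, para to a large group, so it remains open how chloro, bromo, a methoxy group or an amine there would fare in this assay. Also open, going by these compounds, are how far the two fluoro compounds really lie beyond the limit, whether the same exchange would read alike on a third core, and whether changing the fluoro groups elsewhere in these molecules would shift the number at all.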